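A few compounds are considered here, and "the series" means these few. Any claim that something is new, unique, unknown or untested is made for them only; others in the source may bear on it.

Compound 1 `O=C(CCSc1nc2cc(Cl)ccc2o1)N1CCS(=O)(=O)C1` was tested in an ADME assay on microsomes from liver (Homo sapiens) for metabolic stability, read by LC-MS, using NADPH, with a stated time of 45 min, tested at 0.5 uM (a lower number here means slower removal, a higher number faster removal of the compound), and compound 1 gives 1.7 mL/min/g. Compound 2 `O=C1CCCN1CCCSc1nc2cc(Cl)ccc2o1` gives 4.8 mL/min/g in this assay, and compound 3 `O=C(CCSc1nc(-c2ccccc2)co1)N1CCCC1` gives 20.9 mL/min/g. Compound 1 therefore shows the lowest number of the three, and its gaps to compound 2 and to compound 3 both lie beyond the usual scatter. The next compound, compound 4 `CC1CCCN1C(=O)CCSc1nc2cc(Cl)ccc2o1`, has not yet been measured. It differs from compound 1 in one place: 2-methylpyrrolidin-1-yl in place of 1,1-dioxo-1,3-thiazolidin-3-yl on a carbonyl carbon. Within the data shown here, no measured pair shows this exact change. Compound 4 is nevertheless expected to be removed faster than compound 1, a step of a 3.5-fold higher number from compound 1 to compound 4 (0.55 log units; beyond the scatter), because compound 2 already gives 4.8 mL/min/g without the dioxo ring. Compound 4 is thus estimated at 6 mL/min/g, within a range from 2.5 mL/min/g to 15 mL/min/g.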

Compound 4, intrinsic clearance in a liver preparation (reported as CLH), per the amount of preparation that the assay uses: 8.5 mL/min/g
Compound 4: the middle estimate sits 1.4-fold (0.15 log units) below what was measured; measured number inside the range.
By their numbers in this assay, from the lowest: compound 1; then compounds 2 and 4 (each within the scatter of the next); then compound 3.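

With the rest of the molecule held fixed, the group on this carbonyl carbon clearly affects removal: in this assay, 2-methylpyrrolidin-1-yl in place of 1,1-dioxo-1,3-thiazolidin-3-yl gives a 5.0-fold higher number from compound 1 to compound 4 (0.70 log units; beyond the scatter). No measurement shown here explains this rise. Still open, going by these compounds, is whether the step follows from losing the ring's sulfur and oxygen atoms or from gaining the methyl group. On these data alone, how a morpholin-4-yl or a piperidin-1-yl group would behave on the same carbonyl carbon also remains unknown.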